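A Second Oxygen on the Aryl Arm of Compound 3

The source may report more compounds than this note shows. Statements on the series, on what has been measured and on what is new or still open speak of the compounds shown alone.

In an assay on isolated protein for inhibition of Maltase-glucoamylase (Homo sapiens) (a higher number here means a weaker inhibitor, a lower number a stronger inhibitor), compound 1 `O=c1oc2ccc(Cl)cc2c(O)c1C(c1ccc(Cl)cc1Cl)c1c(O)c2cc(Cl)ccc2oc1=O` gives 16500 nM, compound 2 `O=c1oc2ccc(Cl)cc2c(O)c1C(c1cccc([N+](=O)[O-])c1)c1c(O)c2cc(Cl)ccc2oc1=O` gives 27100 nM, and compound 3 `O=c1oc2ccc(Cl)cc2c(O)c1C(c1cccc(O)c1)c1c(O)c2cc(Cl)ccc2oc1=O` gives 84100 nM, the highest of the three numbers, set apart by a 5.1-fold higher number from compound 1 to compound 3 (0.71 log units; beyond the scatter) and by a 3.1-fold higher number from compound 2 to compound 3 (0.49 log units; beyond the scatter). Compound 4 `COc1cc(C(c2c(O)c3cc(Cl)ccc3oc2=O)c2c(O)c3cc(Cl)ccc3oc2=O)ccc1O` differs from compound 3 by 4-hydroxy-3-methoxyphenyl in place of 3-hydroxyphenyl on a saturated chain carbon bound to two aromatic carbons. Going by the values given here, the only step that touches this ring in the same way, a change of what sits on it, is a 3.1-fold higher number from compound 2 to compound 3 (0.49 log units; beyond the scatter), a modest one, and no measured step adds a methoxy anywhere. The group kept in compound 4 still carries the hydroxy of compound 3, so a small step in this assay, if any, is expected, likely within the scatter: a 1.1-fold lower number from compound 3 to compound 4 (0.02 log units; within the scatter). Compound 4 is therefore estimated at 80000 nM, with a range from 30000 nM to 200000 nM.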

Compound 4, half-maximal inhibitory concentration: 83600 nM
Estimate against measurement, compound 4: 1.0-fold (0.02 log units) below; the measured number falls inside the stated range.
By their numbers in this assay, from the lowest: compounds 1 and 2 (each within the scatter of the next); then compounds 4 and 3 (each within the scatter of the next).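

In this assay the 4-hydroxy-3-methoxyphenyl group does what the 3-hydroxyphenyl group did on this saturated chain carbon (a 1.0-fold lower number from compound 3 to compound 4 (0.00 log units; within the scatter)), so this larger group with its methoxy brings no change beyond the scatter. Compound 4 therefore keeps its distance from the other two aryl groups (a 3.1-fold higher number from compound 2 to compound 4 (0.49 log units; beyond the scatter); a 5.1-fold higher number from compound 1 to compound 4 (0.70 log units; beyond the scatter)). Nothing measured here offers a reason for this. The compounds shown do not separate the part of the methoxy from that of the hydroxy, and they leave open what an amine or a carboxylic acid on this aryl ring would do.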